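Aryl exchange at the carbonyl in the cytotoxicity series

A few compounds are considered here, and "the series" means these few. Any claim that something is new, unique, unknown or untested is made for them only; others in the source may bear on it.

Compound 1 `O=C(/C=C/c1ccc2c(c1)B(O)OC2)c1ccc(Cl)cc1` gives 3700 nM in a functional assay on SK-OV-3 cells (Homo sapiens) for cytotoxicity, read by MTT assay, with a stated time of 48 h; a lower number here means a stronger inhibitor, a higher number a weaker inhibitor. Among the three measured compounds it stands second highest; its nearest neighbour is compound 2 `O=C(/C=C/c1ccc2c(c1)B(O)OC2)c1ccc(OCc2ccccc2)cc1` with 6000 nM, its furthest compound 3 `O=C(/C=C/c1ccc2c(c1)B(O)OC2)c1ccc(Cl)c(Cl)c1` with 1800 nM. The step of a 1.6-fold higher number from compound 1 to compound 2 (0.21 log units; within the scatter) sits within the scatter, whereas a 2.1-fold lower number from compound 1 to compound 3 (0.31 log units; beyond the scatter) is a modest gain. Compound 4 `O=C(/C=C/c1ccc2c(c1)B(O)OC2)c1ccccc1O` differs from compound 1 by 2-hydroxyphenyl in place of 4-chlorophenyl on a carbonyl carbon. Neither measured step covers this exchange: the two steps recorded change the 4-chlorophenyl only by benzyloxy in place of chloro or by a second chloro, and both leave the number in a narrow band around compound 1. Going by the values given here, no measured step involves a 2-hydroxyphenyl on the carbonyl carbon, so the hydrogen-bond donor and acceptor that enter are untested here. Among the compounds with values here, the expectation is therefore a number close to compound 1, no step clearly beyond the scatter, with a slight lean toward the higher side. Compound 4 is estimated at 4500 nM, range 1800 nM to 11000 nM, an expected step of a 1.2-fold higher number from compound 1 to compound 4 (0.09 log units; within the scatter).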

Compound 4, half-maximal inhibitory concentration: 48800 nM
Compound 4: the middle estimate sits 11-fold (1.04 log units) below what was measured, and the stated range ends below it.
By their numbers in this assay, from the lowest: compound 3; then compounds 1 and 2 (each within the scatter of the next); then compound 4.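

Unlike the changes on the 4-chlorophenyl, which kept the numbers of compounds 1, 2 and 3 close together, replacing the whole aryl group on the carbonyl carbon in this assay gives a large step: a 13-fold higher number from compound 1 to compound 4 (1.12 log units; beyond the scatter). This position therefore does not tolerate every aryl group, even though the leaving and entering groups both hold 7 heavy atoms and one six-membered aromatic ring. The counted difference is the chlorine leaving, with an oxygen entering as 1 hydrogen-bond donor and 1 hydrogen-bond acceptor, and nothing in hand explains the step.

The exchange changes the substituent and its place on the ring together, so the contribution of each remains unresolved. Unsubstituted phenyl, 4-hydroxyphenyl, 2-chlorophenyl and 2-methoxyphenyl on the same carbonyl carbon would separate these contributions.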